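The compounds below may be only part of what the source reports. "The series", "measured", "known", "first", "only" and "open" are said of these compounds alone.

Of the compounds shown here, two have been measured in an assay on RBL-1 cells with Polyunsaturated fatty acid 5-lipoxygenase (Rattus norvegicus) as the target; on this read-out higher numbers stand for weaker inhibition and lower numbers for stronger inhibition. Compound 1, with the structure `COc1ccc2ccc(Cc3ccccc3)c(O)c2c1`, gives 3500 nM. Compound 2, with the structure `Cc1cc(Cc2ccccc2)c(O)c2ccccc12`, gives 20 nM, which is the lower of the two numbers; the gap to compound 1 is far beyond the usual scatter of repeated measurements. The two structures differ in more than one place, so what separates them cannot be tied to a single change.

Compound 3, with the structure `CS(=O)(=O)c1cc(Cc2ccccc2)c(O)c2ccccc12`, has not yet been measured. Relative to compound 2 it carries methylsulfonyl in place of methyl on an aromatic carbon, that is, methylsulfonyl in place of methyl on an aromatic carbon, a position para to a hydroxy group. Among the measured compounds shown here, no measured pair shows this exact exchange, so its effect has to be guessed. For compound 3, a weaker inhibition than compound 2 is expected, with the step of a 15-fold higher number from compound 2 to compound 3 (1.18 log units; beyond the scatter) lying beyond the scatter. The value for compound 3 in this assay is estimated at 300 nM, within a range from 50 nM to 3000 nM.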

Compound 3, half-maximal inhibitory concentration: 40000 nM
The estimate for compound 3 lay 130-fold (2.12 log units) below the measured number, outside the stated range (above it).
By their numbers in this assay, from the lowest: compound 2; then compound 1; then compound 3.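

In this assay the aromatic carbon para to a hydroxy group proves far from indifferent to what it carries: methylsulfonyl in place of methyl gives a 2000-fold higher number from compound 2 to compound 3 (3.30 log units; beyond the scatter) and thus a large loss of inhibition. Among the compounds shown here, compound 1 and compound 2 differ in more than one place, so this is the first step here that can be tied to a single change at a single carbon. No measurement shown here accounts for the size of this step.

Going by these compounds, whether this loss is particular to methylsulfonyl or would also follow from other groups on this carbon stays open, and an amine, a chlorine atom or a carboxylic acid there could help to tell. On these data alone, it also remains unknown whether the same exchange would have a similar effect on the core of compound 1.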